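Compound 3 to Compound 4: A New Phenyl Group

The source may hold more compounds than are shown below. What is called first, only, known or untested is meant among the compounds shown, and "the series" means these compounds.

In an ADME assay on microsomes from liver (Homo sapiens) for metabolic stability, with a stated time of 60 min, tested at 1 uM (a lower number here means that less of the compound is left, a higher number that more of the compound is left), compound 1 `CS(=O)(=O)Nc1ccc2c(c1)S(=O)(=O)N=C(C1=C(O)[C@@H]3[C@H]4CC[C@H](C4)[C@@H]3N(Cc3ccccc3)C1=O)N2` gives 80%, compound 2 `CS(=O)(=O)Nc1ccc2c(c1)S(=O)(=O)N=C(C1=C(O)[C@@H]3[C@H]4CC[C@H](C4)[C@@H]3N(Cc3ccccc3F)C1=O)N2` gives 89% and compound 3 `Cc1ccc(CN2C(=O)C(C3=NS(=O)(=O)c4cc(NS(C)(=O)=O)ccc4N3)=C(O)[C@@H]3[C@H]4CC[C@H](C4)[C@@H]32)cc1F` gives 78%. Where compound 3 stands is set by two steps: a number 2 percentage points lower from compound 1 to compound 3 (within the scatter), and a number 11 percentage points lower from compound 2 to compound 3 (beyond the scatter). Compound 4 `CS(=O)(=O)Nc1ccc2c(c1)S(=O)(=O)N=C(C1=C(O)[C@@H]3[C@H]4CC[C@H](C4)[C@@H]3N(Cc3ccc(F)c(Cl)c3)C1=O)N2` makes one change to compound 3: 3-chloro-4-fluorophenyl in place of 3-fluoro-4-methylphenyl on a saturated chain carbon bound to an amide-type nitrogen in a ring. The measured steps all alter this same group, so they are the best guide to size. Besides the two above, there is a number 9 percentage points higher from compound 1 to compound 2 (within the scatter). Only one of the three passes the scatter, and only modestly. Going by the values given here, none of them introduces a chloro group, so they offer no direct precedent for this swap. The expected change is small and without a predicted direction beyond the scatter: a number 3 percentage points higher from compound 3 to compound 4 (within the scatter). For compound 4 the estimated value is 81%, with an expected range from 69% to 91%.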

Compound 4, percent of the compound remaining: 87%
Compound 4: middle estimate off by 6 percentage points, on the low side; measured number inside the range.
By their numbers in this assay, from the lowest: compounds 3, 1, 4 and 2 (each within the scatter of the next, the first and the last beyond it).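

Compound 4 is the only one here with a chloro group at this place, on a saturated chain carbon bound to an amide-type nitrogen in a ring, and in this assay all three of its steps stay within the scatter: a number 9 percentage points higher from compound 3 to compound 4 (within the scatter), a number 2 percentage points lower from compound 2 to compound 4 (within the scatter) and a number 7 percentage points higher from compound 1 to compound 4 (within the scatter). Going by these compounds alone, compound 4 thus lies within the scatter of each of the others, including compound 2 and compound 3, the one pair that stands apart. Nothing available gives a reason for where its number falls.

On these data alone, it remains open whether the number would stay in this band if the phenyl ring carried an amine or a carboxylic acid instead of halogen or methyl. As far as these compounds go, how a longer chain in place of the benzyl group would read here is also open.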